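Glycine Ester on a Shared Core: Another Limit Expected

The compounds below may be only part of what the source reports. "The series", "measured", "known", "first", "only" and "open" are said of these compounds alone.

Compound 1, `C=C1CC[C@H]2[C@@](C)(CC[C@@H](OC(=O)c3cccnc3)[C@@]2(C)NC=O)[C@@H]1/C=C/C1=CCOC1=O`, in an assay for inhibition of hexokinase-2 (Homo sapiens), read by coupled enzyme assay, with a stated time of 10 min, in the presence of a further agent that is not named here (a higher number here means a weaker inhibitor, a lower number a stronger inhibitor), gives only a limit, > 50000 nM.
Compound 2, `C=C1CC[C@H]2[C@@](C)(CC[C@@H](OC(=O)c3ccc([N+](=O)[O-])cc3)[C@@]2(C)NC=O)[C@@H]1/C=C/C1=CCOC1=O`, in this assay gives only a limit, > 50000 nM.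
Compound 3, `C=C1CC[C@H]2[C@@](C)(CC[C@@H](OC(=O)[C@H](N)CC(C)C)[C@@]2(C)NC=O)[C@@H]1/C=C/C1=CCOC1=O`, in this assay gives only a limit, > 50000 nM.

Compound 3 stands where every measured compound stands: at the limit of > 50000 nM in this assay, at which 3 of the 3 values shown sit. No measured step can be read in size, since each joins two limits: a step that the two limits leave unreadable from compound 1 to compound 2, a step that the two limits leave unreadable from compound 1 to compound 3, a step that the two limits leave unreadable from compound 2 to compound 3. Three quite different groups on the carbonyl carbon all leave the value at the limit, and none of them shows a direction.

Compound 4, `C=C1CC[C@H]2[C@@](C)(CC[C@@H](OC(=O)CN)[C@@]2(C)NC=O)[C@@H]1/C=C/C1=CCOC1=O`, differs from compound 3 by hydrogen in place of isobutyl on a saturated chain carbon bound to an amine nitrogen and a carbonyl carbon. This is a smaller change than any of the measured ones, and the measured steps give no sign that the ester group moves the value at all. The step from compound 3 to compound 4 is expected to be none beyond the scatter, a step that the limit leaves unreadable from compound 3 to compound 4. Compound 4 is estimated at 70000 nM, within 20000 nM to 300000 nM, and most likely reported once more only as a limit.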

Compound 4, half-maximal inhibitory concentration: > 50000 nM
Compound 4: a limit, no number (the forecaster's own chance of this, stated with the estimate: 85%); the middle value lies beyond the limit too.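

Compound 4 also gives only a limit in this assay, so its steps from compound 1, compound 2 and compound 3 cannot be read in size: the limit of > 50000 nM in this assay, at which 4 of the 4 values shown sit.

The compounds shown leave open how far beyond that limit each one lies, and whether any ester on the shared core gives a measurable value.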